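This account rests on a few compounds, and the source may have more. Where it says the series, first, only, none or still open, it means among the compounds named here.

Measured compounds in an ADME assay on HEK293 cells (Homo sapiens) for cytotoxicity, with a stated time of 6 h; a higher number here means that more compound is tolerated, a lower number that less compound is tolerated:

compound 1, `CCCCCNc1nc(N)nc2ccccc12`, gives > 25000 nM, a limit of the assay.
compound 2, `CC(C)CCNc1nc(N)nc2ccccc12`, gives > 25000 nM, a limit of the assay.
compound 3, `CCCCNc1nc(N)nc2cccc(C)c12`, gives > 25000 nM, a limit of the assay.

Compound 3 therefore stands where every measured value of the series stands, namely at the limit of > 25000 nM in this assay, at which 3 of the 3 values shown sit; no number has been read for it, only the limit. Going by the values given here, the one step between measured compounds, a step that the two limits leave unreadable from compound 1 to compound 2, is unreadable for the same reason, both its ends being limits, so its size is not known.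

The unmeasured compound 4, `CCCCNc1nc(N)nc2cccc(C(=O)N(C)C(C)C)c12`, differs from compound 3 in one place: isopropyl(methyl)carbamoyl in place of methyl on an aromatic carbon. Among the compounds with values here, no measured step touches this aromatic carbon, and the single step that was measured, the change from propyl to isopropyl on the saturated chain, gives no readable size. There is thus nothing in the numbers that points in either direction for the new change. The expectation for compound 4 in this assay is that it also sits at the limit, so the step that the limit leaves unreadable from compound 3 to compound 4 is expected to be none beyond the scatter. Compound 4 is estimated at 40000 nM, within 15000 nM to 120000 nM, most likely reported again only as a limit.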

Compound 4, half-maximal cytotoxic concentration: > 25000 nM
Compound 4: a limit, no number; the forecaster's own chance of this, stated with the estimate: 85%; the middle value lies beyond the limit too.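

In this assay compound 4 gives > 25000 nM, a limit of the assay and not a number. The change from compound 3 to compound 4 therefore yields no readable step, both ends being limits: the limit of > 25000 nM in this assay, at which 4 of the 4 values shown sit.

Still open, as far as these compounds go, is the concentration at which compound 1, compound 2, compound 3 or compound 4 turns cytotoxic, and whether either change shifts it.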